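From methoxy to dimethylamino on a shared core

The source may hold more compounds than are shown below. What is called first, only, known or untested is meant among the compounds shown, and "the series" means these compounds.

Readings so far in a functional assay on MCF7 cells (Homo sapiens) for inhibition, read by sulforhodamine B assay (a higher number here means a weaker inhibitor of growth, a lower number a stronger inhibitor of growth), are these:
compound 1 `FC(F)(F)Oc1ccc(-c2ccc(-c3ccc(-c4nc5ccccc5[nH]4)cc3)cc2)cc1` gives 38400 nM
compound 2 `COc1ccc(-c2ccc(-c3ccc(-c4nc5ccccc5[nH]4)cc3)cc2)cc1` gives 33300 nM

Compound 2 has only compound 1 to stand against on these numbers, and the two lie within the scatter of each other, so neither can be ranked ahead. Compound 3 `CN(C)c1ccc(-c2ccc(-c3ccc(-c4nc5ccccc5[nH]4)cc3)cc2)cc1` keeps the core of compound 2 and carries dimethylamino in place of methoxy on an aromatic carbon, para to a large group (dimethylamino in place of methoxy on an aromatic carbon). For the measured compounds named here, one measured step bears on this change: a 1.2-fold lower number from compound 1 to compound 2 (0.06 log units; within the scatter) is the only one available, and it altered the group on the oxygen of that same end of the molecule. That single step stayed within the scatter. Going by the values given here, no measured compound carries dimethylamino, so the data offer no direction for this swap, and no shift beyond the scatter is expected in this assay. The expected change is a 1.1-fold lower number from compound 2 to compound 3 (0.05 log units; within the scatter) and amounts to no real separation. The estimate for compound 3 is 30000 nM (expected range 13000 nM to 65000 nM).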

Compound 3, concentration for 50% growth inhibition: 41200 nM
The estimate for compound 3 lay 1.4-fold (0.14 log units) below the measured number, within the range that was stated.
By their numbers in this assay, from the lowest: compounds 2, 1 and 3 (each within the scatter of the next).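

In this assay putting dimethylamino in place of methoxy on an aromatic carbon, para to a large group, gives a 1.2-fold higher number from compound 2 to compound 3 (0.09 log units; within the scatter) and putting it in place of trifluoromethoxy gives a 1.1-fold higher number from compound 1 to compound 3 (0.03 log units; within the scatter) so the three compounds remain inseparable at this position. The earlier pair had shown only that the group on the oxygen could change without a shift beyond the scatter, whereas the change from 4-methoxyphenyl to 4-(dimethylamino)phenyl now shows the same when nitrogen replaces oxygen as the atom joined to the ring. No evidence at hand accounts for how closely these readings sit together.

As far as these compounds go, whether another kind of group at this position, such as a carboxylic acid, a primary amine or a longer chain, would carry the number beyond the scatter remains open. Also open, from the compounds shown here alone, is whether a change elsewhere on the shared core would separate compounds in a way that these three substitutions at one end of the molecule do not.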